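A few compounds are considered here, and "the series" means these few. Any claim that something is new, unique, unknown or untested is made for them only; others in the source may bear on it.

Of the compounds shown here, two of a shared core have been tested. Compound 1 `Oc1ccc(-c2cc(-c3cccc(Cl)c3)nc(-c3cccs3)c2)cc1` in a functional assay on T47D cells (Homo sapiens) for cytotoxicity, read by CCK-8 assay and cell counting, with a stated time of 2 days (on this read-out higher numbers stand for weaker inhibition and lower numbers for stronger inhibition), gives 5350 nM. Compound 2 `Oc1cccc(-c2cc(-c3cccc(Cl)c3)nc(-c3ccco3)c2)c1` in this assay gives 3570 nM, a number that sits close to that of compound 1, inside the usual scatter. Compound 3 `Oc1cccc(-c2cc(-c3cccc(Cl)c3)nc(-c3cccs3)c2)c1` differs from compound 2 in one place: thiophen-2-yl in place of furan-2-yl on an aromatic carbon. For the measured compounds named here, with no measured pair showing this exact exchange, and the two known numbers lying so close together, the expected step of a 1.3-fold higher number from compound 2 to compound 3 (0.10 log units; within the scatter) is none beyond the scatter. For compound 3 the estimate in this assay is 4500 nM, expected within 2000 nM to 10000 nM.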

Compound 3, half-maximal inhibitory concentration: 3410 nM
Compound 3: middle estimate off by 1.3-fold (0.12 log units), on the high side; measured number inside the range.
By their numbers in this assay, from the lowest: compounds 3, 2 and 1 (each within the scatter of the next).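

Replacing furan-2-yl with thiophen-2-yl on this carbon next to the ring nitrogen gives a 1.0-fold lower number from compound 2 to compound 3 (0.02 log units; within the scatter) in this assay, so these two five-membered aromatic rings cannot be told apart here. Replacing 4-hydroxyphenyl with 3-hydroxyphenyl gives a 1.6-fold lower number from compound 1 to compound 3 (0.20 log units; within the scatter), so that exchange cannot be separated from the scatter either. No supporting data bear on why both steps are so small.

On these data alone, whether a non-aromatic group at this position, such as an amine or a carboxylic acid, would shift the number remains open. As far as these compounds go, the role of the 3-chlorophenyl group also remains open, as all three compounds carry it.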